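Nucleoside series: sulfur-linked substituents and cytotoxicity

This account rests on a few compounds, and the source may have more. Where it says the series, first, only, none or still open, it means among the compounds named here.

Measured compounds:
compound 1 `OC[C@H]1O[C@@H](n2cnc3c(CSc4ccccn4)ncnc32)[C@H](O)[C@@H]1O` gives > 100000 nM
compound 2 `O=c1ccccn1Cc1ncnc2c1ncn2[C@@H]1O[C@H](CO)[C@@H](O)[C@H]1O` gives > 100000 nM
compound 3 `O=C1CCCN1Cc1ncnc2c1ncn2[C@@H]1O[C@H](CO)[C@@H](O)[C@H]1O` gives 45000 nM

In a functional assay on Huh-7 cells (Homo sapiens) for cytotoxicity, read by MTT assay, with a stated time of 3 days (on this read-out lower numbers stand for higher toxicity in this test and higher numbers for lower toxicity in this test), compound 1 is known only as a limit, its value standing at the ceiling of the test. Compound 2 likewise reports only a limit. Among the measured compounds shown here, compound 3 is the one compound of the three with a number, and the steps to it are an at least 2.2-fold lower number from compound 1 to compound 3 (0.34 log units; beyond the scatter) and an at least 2.2-fold lower number from compound 2 to compound 3 (0.34 log units; beyond the scatter); the step that the two limits leave unreadable from compound 1 to compound 2 cannot be sized. The shared reading at the limit of > 100000 nM in this assay, at which 2 of the 3 values shown sit, means that for compound 1 there is no number to move from, only a floor for its value.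

The change to compound 4 `CSCc1ncnc2c1ncn2[C@@H]1O[C@H](CO)[C@@H](O)[C@H]1O` is methyl in place of pyridin-2-yl on a sulfur. For the measured compounds named here, no measured step trims the sulfur substituent in this way; the three measured steps swap out the whole group on the saturated chain carbon bound to an aromatic carbon, so none bears directly on it. Going by the values given here, the only readable steps show that replacing the (pyridin-2-yl)sulfanyl group with 2-oxopyrrolidin-1-yl lowers the number at least modestly, while the pyridin-2-yl-to-pyridinone swap stays unreadable at the limit.

With nothing pointing to a gain in toxicity, compound 4 is expected to stay near the limit, the step of a number no higher from compound 1 to compound 4 (the limit leaves the size open) being essentially none beyond the scatter. Compound 4 is accordingly estimated at 100000 nM, within 40000 nM to 250000 nM, with a limit reading the likeliest outcome.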

Compound 4, half-maximal cytotoxic concentration: > 100000 nM
Compound 4 ended at the assay's limit; the forecaster's own chance of this, stated with the estimate: 60%; the middle value lies on the limit itself.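

In this assay compound 4 gives > 100000 nM, which is a limit of the assay and not a number. Among the compounds shown here, a reading at the limit therefore does not depend on the pyridin-2-yl ring on the sulfur, and methylsulfanyl in place of 2-oxopyrrolidin-1-yl on the saturated chain carbon bound to an aromatic carbon gives an at least 2.2-fold higher number from compound 3 to compound 4 (0.34 log units; beyond the scatter), so a sulfur-linked group with no ring also stands clear of the one measured number. The steps to compound 4 from compound 1 and from compound 2 cannot be read, and the series now crowds at one end of the scale: the limit of > 100000 nM in this assay, at which 3 of the 4 values shown sit.

Any true difference between methyl and pyridin-2-yl on a sulfur remains hidden at the limit, so the size of that change stays open. Also open, from the compounds shown here alone, is whether the lower number of compound 3 is particular to 2-oxopyrrolidin-1-yl, or whether an amine or a carboxylic acid on the saturated chain carbon, or a longer chain on the sulfur, would also bring a reading down from the limit.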